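A few compounds are considered here, and "the series" means these few. Any claim that something is new, unique, unknown or untested is made for them only; others in the source may bear on it.

Measured compounds in an ADME assay on HepG2 cells (Homo sapiens) for cytotoxicity, read by luminescence, CellTiter-Glo and ATP content, with a stated time of 72 h; on this read-out lower numbers stand for an effect already at smaller amounts and higher numbers for an effect only at larger amounts of compound:
compound 1, `FC(F)(F)c1ccc(-c2ccc3c(NCCCNCc4ccco4)ccnc3c2)cc1`, 3470 nM
compound 2, `COc1ccc(F)cc1CNCCCNc1ccnc2cc(-c3ccc(C(F)(F)F)cc3)ccc12`, 5190 nM

Compound 1 and compound 2 share the same core and the same chain; they differ only at the benzylic end of that chain, and a 1.5-fold higher number from compound 1 to compound 2 (0.17 log units; within the scatter) leaves the two values within the usual scatter of each other. Compound 1 therefore stands on a par with compound 2, and nothing in these two numbers sets one above the other.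

Compound 3, `N#Cc1ccc(Cc2ccc3c(NCCCNCc4ccco4)ccnc3c2)cc1`, departs from compound 1 at the opposite end of the molecule: 4-cyanobenzyl in place of 4-(trifluoromethyl)phenyl on an aromatic carbon. Among the compounds with values here, no measured step touches this position; the only step on record, from compound 1 to compound 2, changes the benzylic aryl group on the chain and so says little about the aryl group on the core. Within the data shown here, with no bearing step, the expected change in this assay is none beyond the scatter, but the uncertainty is wider than for a well-documented change, so the range is set broad.

Compound 3 is expected to give about 4000 nM in this assay, between 1500 nM and 12000 nM, which corresponds to an estimated step of a 1.2-fold higher number from compound 1 to compound 3 (0.06 log units; within the scatter).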

Compound 3, half-maximal effective concentration: 7910 nM
For compound 3 the middle estimate is 2.0-fold (0.30 log units) below the measured one; low and high end bracket the measured number.
By their numbers in this assay, from the lowest: compounds 1, 2 and 3 (each within the scatter of the next, the first and the last beyond it).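

In this assay, within the data shown here, this position on the shared core does respond to substitution: 4-cyanobenzyl in place of 4-(trifluoromethyl)phenyl gives a 2.3-fold higher number from compound 1 to compound 3 (0.36 log units; beyond the scatter), a modest step, whereas the only earlier change, on the chain, gave a 1.5-fold higher number from compound 1 to compound 2 (0.17 log units; within the scatter). The change at this aromatic carbon alters several things at once, since the entering group adds a triple bond and a hydrogen-bond acceptor and the three fluorine atoms leave, so this single step cannot assign the shift to any one of these features. No measurement available here bears on why the number moves.

The compounds shown leave open whether the shift follows the nitrile or the benzyl form of the group, a question that a cyanophenyl group and a (trifluoromethyl)benzyl group at this position would separate. They also leave open whether the same step would appear with the 5-fluoro-2-methoxyphenyl group of compound 2 on the chain, and how a carboxylic acid in place of the nitrile or a longer chain would read in this assay.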